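Fluoro to trifluoromethyl on the aryl ring of compound 2

The compounds below may be only part of what the source reports. "The series", "measured", "known", "first", "only" and "open" are said of these compounds alone.

Compound 1 `O=C(O)CCCCCC[C@@H]1[C@@H](CC[C@@H](O)CCc2cccc(F)c2)[C@H](O)C[C@@H]1O` gives 42 nM in an in vitro assay on CHO-KI cells for displacement of a labelled ligand from prostaglandin F2-alpha receptor (Homo sapiens); on this read-out higher numbers stand for weaker inhibition and lower numbers for stronger inhibition. Compound 2 `O=C(O)CCCCCC[C@@H]1[C@@H](CC[C@@H](O)CCc2ccc(F)cc2)[C@H](O)C[C@@H]1O` gives 210 nM in this assay, the higher of the two numbers. Going by the values given here, the one step in hand, a 5.0-fold higher number from compound 1 to compound 2 (0.70 log units; beyond the scatter), does not exchange the group itself, so it sets only a scale. Compound 3 `O=C(O)CCCCCC[C@@H]1[C@@H](CC[C@@H](O)CCc2ccc(C(F)(F)F)cc2)[C@H](O)C[C@@H]1O` differs from compound 2 by trifluoromethyl in place of fluoro on an aromatic carbon, para to a large group. Among the compounds with values here, no measured step covers this exchange. The step of a 1.5-fold higher number from compound 2 to compound 3 (0.18 log units; within the scatter) is therefore expected to be small, at or just beyond the scatter, toward a higher number. Compound 3 is estimated at 320 nM, range 80 nM to 1300 nM.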

Compound 3, half-maximal inhibitory concentration: 3630 nM
Compound 3: the middle estimate sits 11-fold (1.05 log units) below what was measured; the measured number lies above the stated range.
By their numbers in this assay, from the lowest: compound 1; then compound 2; then compound 3.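

In this assay the aromatic carbon para to a large group proves far more sensitive to this exchange than the earlier pair suggested: trifluoromethyl in place of fluoro gives a large step (a 17-fold higher number from compound 2 to compound 3 (1.24 log units; beyond the scatter)) where the fluoro shift gave only a modest one (a 5.0-fold higher number from compound 1 to compound 2 (0.70 log units; beyond the scatter)). Set against the 3-fluorophenyl of compound 1, 4-(trifluoromethyl)phenyl opens the widest gap in the series (an 86-fold higher number from compound 1 to compound 3 (1.94 log units; beyond the scatter)) and leaves compound 3 with the highest number of the three. Nothing at hand accounts for this loss.

As far as these compounds go, whether chloro or methyl on the same carbon would fall nearer compound 2 or compound 3 stays open. Also open, from the compounds shown here alone, is what trifluoromethyl would give in place of the fluoro of compound 1.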